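The compounds below may be only part of what the source reports. "The series", "measured", "known", "first", "only" and "open" are said of these compounds alone.

In a functional assay on NCI-H1650 cells (Homo sapiens) for inhibition, read by sulforhodamine B assay, with a stated time of 3 days (on this read-out lower numbers stand for stronger inhibition and higher numbers for weaker inhibition), three compounds have been measured:
compound 1 `O=C1Nc2ccc(F)cc2/C1=C\C(=O)c1ccc(C2CCCCC2)cc1` at 2730 nM
compound 2 `O=C1Nc2ccc([N+](=O)[O-])cc2/C1=C\C(=O)c1ccc(C2CCCCC2)cc1` at 3860 nM
compound 3 `CN1CCN(c2cccc(N/C=C3\C(=O)Nc4ccc(NC(=O)c5cccc(F)c5)cc43)c2)CC1` at 4280 nM

Compound 3 with 4280 nM lies within the scatter of both compound 1 and compound 2. Compound 4 `CN1CCN(c2cccc(N/C=C3\C(=O)Nc4ccc(NC(=O)c5ccc[nH]5)cc43)c2)CC1` differs from compound 3 by 1H-pyrrol-2-yl in place of 3-fluorophenyl on a carbonyl carbon. For the measured compounds named here, no measured step covers this change. The only one available is a 1.4-fold higher number from compound 1 to compound 2 (0.15 log units; within the scatter) and it lies within the scatter, but it concerns nitro in place of fluoro on an aromatic carbon, so it bears only loosely. No shift beyond the scatter is therefore expected. The estimated step is a 1.2-fold lower number from compound 3 to compound 4 (0.09 log units; within the scatter) and it carries no clear direction. For compound 4 the expected value is 3500 nM (estimated range 1300 nM to 9000 nM).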

Compound 4, half-maximal inhibitory concentration: 7560 nM
Compound 4: the middle estimate sits 2.2-fold (0.33 log units) below what was measured; the range from low to high includes it.
By their numbers in this assay, from the lowest: compounds 1, 2, 3 and 4 (each within the scatter of the next, the first and the last beyond it).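

In this assay the carbonyl carbon on the amide-type nitrogen carries either 3-fluorophenyl or 1H-pyrrol-2-yl, and this exchange gives a 1.8-fold higher number from compound 3 to compound 4 (0.25 log units; within the scatter). For the compounds shown here, this is the first step read at this position, and it shows that a five-membered aromatic ring with one hydrogen-bond donor can replace a six-membered aromatic ring of carbon only without a shift beyond the scatter. Nothing available accounts for the size of this step.

Going by these compounds, whether a saturated amine such as piperidin-4-yl or a carboxylic acid at this place would move the number beyond the scatter stays open.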